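A few compounds are considered here, and "the series" means these few. Any claim that something is new, unique, unknown or untested is made for them only; others in the source may bear on it.

Compound 1 `CC1=CC[C@H](C(C)C)c2cc(C)c(OC(=O)Nc3ccccc3)cc21` stands highest among the three compounds measured in a functional assay on SK-LU-1 cells (Homo sapiens) for antiproliferative activity, read by sulforhodamine B assay, with a stated time of 48 h, tested at 50 uM; a higher number here means more inhibition at the concentration tested (going by the name of the read-out), a lower number less inhibition: compound 1 gives 100%. The other two measured compounds are built on a different core, so neither is a single-change neighbour of compound 1. Among the compounds with values here, compound 2 `Cc1cc2c(C(C)C)ccc(C)c2cc1OC(=O)c1ccc(C(F)(F)F)cc1` gives 28.7% in this assay, and compound 3 `COc1cccc(C(=O)Oc2cc3c(C)ccc(C(C)C)c3cc2C)c1` gives 30.6%; both values lie far below that of compound 1, beyond the scatter, but the two structures differ from compound 1 in more than one place, so no step can be drawn from them.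

Compound 4 `CC1=CC[C@H](C(C)C)c2cc(C)c(OC(=O)c3cccc(Cl)c3)cc21` has not yet been measured. It keeps the core of compound 1 and differs from it in one place: 3-chlorophenyl in place of anilino on a carbonyl carbon. Within the data shown here, no measured pair isolates this change. The anilino group is present in compound 1 alone, and compounds 2 and 3, which lack it, both sit low, though the core also differs there. The step is therefore expected to go downward and beyond the scatter, with the change from compound 1 to compound 4 estimated at a number 40 percentage points lower from compound 1 to compound 4 (beyond the scatter). Compound 4 is expected to give about 60% in this assay, within a range from 30% to 95%.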

Compound 4, a percentage reported as inhibition, at one concentration (the size of the read-out at that concentration, not a potency): 30.6%
The estimate for compound 4 lay 29.4 percentage points above the measured number, within the range that was stated.
By their numbers in this assay, from the lowest: compounds 2, 3 and 4 (each within the scatter of the next); then compound 1.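

Within the data shown here, with the core held fixed, replacing anilino with 3-chlorophenyl on a carbonyl carbon gives a number 69.4 percentage points lower from compound 1 to compound 4 (beyond the scatter) in this assay, the first step at this position that can be read on its own. The two groups have the same heavy-atom count and each carries one six-membered aromatic ring of carbon only, yet they differ in nitrogen against chlorine and in the hydrogen-bond donor that anilino alone has, and this single pair cannot separate those differences. No measurement bearing on the cause of this large loss accompanies the step.

Still open, from the compounds shown here alone, is whether N-methylanilino, which keeps the nitrogen but not its hydrogen, or benzylamino would hold the level of compound 1. Unsubstituted phenyl at this place would likewise show what the chlorine contributes to compound 4.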